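A few compounds are considered here, and "the series" means these few. Any claim that something is new, unique, unknown or untested is made for them only; others in the source may bear on it.

Working notes on the series.

Three compounds carry numbers in a functional assay on the whole organism (strain Swiss albino) with Mus musculus as the target, with stated times of 30 min and 10 min, at a dose of 50 mg/kg by the oral route; on this read-out lower numbers stand for less inhibition and higher numbers for more inhibition at the one dose given (going by the name of the read-out). Compound 1 `CC(=O)c1c(NNc2ccc(Br)cc2)cc(C)oc1=O` gives 53.1%. Compound 2 `CC(=O)c1c(NNc2nc(C)cc(C)n2)cc(C)oc1=O` gives 64.9%. Compound 3 `Cc1cc2nn(-c3ccccc3)c(C)c2c(=O)o1` gives 50.2%, the lowest of the three numbers; the gap to compound 1 lies within the scatter, so no order between those two can be read, while the gap to compound 2 lies beyond the scatter. Going by the values given here, no pair of measured compounds differs in a single place, so no step between them is known.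

Compound 4 `Cc1cc2nn(-c3ccc(Br)cc3)c(C)c2c(=O)o1` is not yet measured in this assay. It differs from compound 3 in one place, (bromo in place of hydrogen on an aromatic carbon). Nothing measured in the series isolates this change; the bromo-bearing compound 1 and the unsubstituted compound 3 differ in more than one place and their numbers sit within the scatter of each other. The expected step from compound 3 to compound 4 is therefore small, a number 3.8 percentage points higher from compound 3 to compound 4 (within the scatter), not clearly beyond the scatter in either direction. For compound 4 the estimate is 54%, with a range from 42% to 66%.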

Compound 4, a percentage reported as inhibition, in the whole organism at one dose (the size of the read-out at that dose, not a potency): 44.9%
Estimate against measurement, compound 4: 9.1 percentage points above; the range from low to high includes it.
By their numbers in this assay, from the lowest: compounds 4, 3 and 1 (each within the scatter of the next); then compound 2.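

Going by these compounds alone, the first single-place step comes from bromo in place of hydrogen on an aromatic carbon, para to a large group: in this assay the change gives a number 5.3 percentage points lower from compound 3 to compound 4 (within the scatter). At the one dose given, this place on the six-membered aromatic ring of carbon only therefore accepts a bromine atom without a shift that can be told from the scatter, though a small effect in either direction is not excluded. No measurement on hand bears on the reason for the size of this step.

As far as these compounds go, whether an amine, a carboxylic acid or a longer chain at the same place would give a step beyond the scatter remains open. Also open, from the compounds shown here alone, is whether bromo behaves the same way at other places on this ring, since this single pair covers one place and one dose only.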